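This account rests on a few compounds, and the source may have more. Where it says the series, first, only, none or still open, it means among the compounds named here.

Compound 1, `O=C(CCC(=O)OCCCCCCSc1ccc([N+](=O)[O-])c2nonc12)Nc1ccccc1`, gives in an assay on isolated protein for inhibition of glutathione S-transferase P (Homo sapiens), with a stated time of 10 min (a higher number here means a weaker inhibitor, a lower number a stronger inhibitor), a value of 10200 nM.
Compound 2, `Cc1ccccc1NC(=O)CCC(=O)OCCCCCCSc1ccc([N+](=O)[O-])c2nonc12`, gives in this assay a value of 4100 nM.
Compound 3, `O=C(CCC(=O)OCCCCCCSc1ccc([N+](=O)[O-])c2nonc12)Nc1ccc(C(F)(F)F)cc1`, gives in this assay a value of 5050 nM.

Compound 1 has the highest number of the three, so it is the weakest inhibitor here. The two steps away from it, a 2.5-fold lower number from compound 1 to compound 2 (0.40 log units; beyond the scatter) and a 2.0-fold lower number from compound 1 to compound 3 (0.31 log units; beyond the scatter), both add a group to the phenyl and keep the ring. Compound 4, `CN(C)CCCNC(=O)CCC(=O)OCCCCCCSc1ccc([N+](=O)[O-])c2nonc12`, goes further: 3-(dimethylamino)propyl in place of phenyl on an amide-type nitrogen. Among the measured compounds shown here, no measured step removes the ring, so nothing here says how this change acts, and the expectation is only that the number stays near that of compound 1, with wide doubt. The step expected is a 1.5-fold higher number from compound 1 to compound 4 (0.17 log units; within the scatter). Compound 4 is thus estimated at 15000 nM, between 4000 nM and 60000 nM.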

Compound 4, half-maximal inhibitory concentration: 160 nM
Beside the measured number, compound 4's estimate is 94-fold (1.97 log units) above it, and the stated range ends above it.
By their numbers in this assay, from the lowest: compound 4; then compounds 2 and 3 (each within the scatter of the next); then compound 1.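

On an amide-type nitrogen, the phenyl ring is not needed for inhibition: 3-(dimethylamino)propyl in its place gives a 64-fold lower number from compound 1 to compound 4 (1.80 log units; beyond the scatter), far larger than the modest steps seen when groups were added to the ring. The open chain also outdoes both substituted rings, with a 32-fold lower number from compound 3 to compound 4 (1.50 log units; beyond the scatter) and a 26-fold lower number from compound 2 to compound 4 (1.41 log units; beyond the scatter). Nothing available explains this gain.

Still open, from the compounds shown here alone, is whether the amine or the loss of the ring matters, which a plain hexyl chain would help separate. Going by these compounds, a shorter or longer chain carrying the dimethylamino group also remains untested here.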